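A Methyl Group Added to Compound 2

The compounds below may be only part of what the source reports. "The series", "measured", "known", "first", "only" and "open" are said of these compounds alone.

In a functional assay on A549 cells (Homo sapiens) for cytotoxicity, read by MTT assay, with a stated time of 72 h (on this read-out higher numbers stand for weaker inhibition and lower numbers for stronger inhibition), compound 1 (`COC(=O)c1sc2c(C)cccc2c1Nc1cc(OC)c(OC)c(OC)c1`) gives 3930 nM, while compound 2 (`CCOC(=O)c1sc2ccccc2c1Nc1cc(OC)c(OC)c(OC)c1`) gives 8530 nM, the higher of the two numbers and thus the weaker inhibition. Compound 3 (`CCOC(=O)c1sc2cccc(C)c2c1Nc1cc(OC)c(OC)c(OC)c1`) departs from compound 2 by a single change, methyl in place of hydrogen on an aromatic carbon. Within the data shown here, compound 1 and compound 2 differ in more than one place, so no measured step isolates this change. In this assay, the expected change is small and toward a lower number, within the scatter, with an estimated 1.4-fold lower number from compound 2 to compound 3 (0.15 log units; within the scatter). Compound 3 is expected to give 6000 nM, within an estimated range of 2500 nM to 15000 nM.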

Compound 3, half-maximal inhibitory concentration: 6250 nM
For compound 3 the middle estimate is 1.0-fold (0.02 log units) below the measured one; measured number inside the range.
By their numbers in this assay, from the lowest: compounds 1, 3 and 2 (each within the scatter of the next, the first and the last beyond it).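

In this assay, among these compounds, methyl in place of hydrogen on an aromatic carbon, ortho to a fused ring and meta to a fused ring, gives a 1.4-fold lower number from compound 2 to compound 3 (0.14 log units; within the scatter) and is the first step to isolate this change, since compound 1 and compound 2 differ in more than one place. At this position, the added methyl therefore separates the two compounds by no more than the usual scatter. No available evidence bears on the reason for this result.

The compounds shown leave open whether an amine, a carboxylic acid or a longer chain at this position would stay within the scatter of compound 2. They also leave open how methyl would read on the other aromatic carbons of this ring.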